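Aryl in place of the dichlorostyryl arm on the shared core

The source may hold more compounds than are shown below. What is called first, only, known or untested is meant among the compounds shown, and "the series" means these compounds.

Measured so far:
compound 1 `COC(=O)/C=C/c1cccc(N(Cc2ccc(/C=C/c3c(Cl)cccc3Cl)cc2)C(=O)C(C)C)c1`: 195 nM
compound 2 `COC(=O)/C=C/c1cccc(N(Cc2ccc(/C=C/c3ccccc3F)cc2)C(=O)NC(C)C)c1`: 431 nM
compound 3 `COC(=O)/C=C/c1cccc(N(Cc2ccc(/C=C/c3scnc3C)cc2)C(=O)C2CCCCC2)c1`: 227 nM

In an assay on isolated protein with Bile acid receptor (Homo sapiens) as the target (on this read-out lower numbers stand for an effect already at smaller amounts and higher numbers for an effect only at larger amounts of compound), compound 1 gives 195 nM. Compound 3 gives 227 nM, which lies within the scatter of compound 1. Compound 2 gives 431 nM, a gap from compound 1 that is beyond the scatter. Compound 4 `COC(=O)/C=C/c1cccc(N(Cc2ccc(-c3ccc(OC)cc3)cc2)C(=O)C(C)C)c1` is not yet measured. It differs from compound 1 in one place: 4-methoxyphenyl in place of 2-(2,6-dichlorophenyl)ethenyl on an aromatic carbon. The ethenyl link and the chlorines leave, and a 4-methoxyphenyl enters on the same aromatic carbon. Among the compounds with values here, no measured pair shows what this change does, so the expectation rests on compound 1 alone. The step from compound 1 to compound 4 in this assay is expected to be a 2.8-fold higher number from compound 1 to compound 4 (0.45 log units; beyond the scatter), toward a higher number and beyond the scatter. For compound 4 the estimate is 550 nM, with a range from 160 nM to 1900 nM.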

Compound 4, half-maximal effective concentration: 97 nM
The estimate for compound 4 lay 5.7-fold (0.75 log units) above the measured number; measured number below the stated range.
By their numbers in this assay, from the lowest: compounds 4, 1, 3 and 2 (each within the scatter of the next, the first and the last beyond it).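

Putting 4-methoxyphenyl in place of 2-(2,6-dichlorophenyl)ethenyl, on the aromatic carbon para to a large group, gives in this assay a 2.0-fold lower number from compound 1 to compound 4 (0.30 log units; within the scatter). This position therefore tolerates losing the ethenyl link and both chlorines together, with an aryl group attached directly. No available data explain this result.

Within the data shown here, the single step cannot separate the ethenyl link from the chlorines. Also open, going by these compounds, is whether a carboxylic acid or an amine on the entering ring, in place of the methoxy group, would keep the number in this range.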